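A few compounds are considered here, and "the series" means these few. Any claim that something is new, unique, unknown or untested is made for them only; others in the source may bear on it.

Compound 1 `COc1cc(-c2cc(/C=C/C(=O)c3ccc(N)cc3)[nH]n2)cc(OC)c1OC`: 106%
Compound 2 `COc1ccc(C(=O)/C=C/c2cc(-c3cc(OC)c(OC)c(OC)c3)n[nH]2)cc1OC`: 99%
Compound 3 `COc1ccc(C(=O)/C=C/c2cc(-c3cc(OC)c(OC)c(OC)c3)n[nH]2)cc1`: 102%

These three numbers all come from a functional assay on NCI/ADR-RES cells (Homo sapiens) for cytotoxicity, read by sulforhodamine B assay, with a stated time of 48 h, tested at 0.01 uM; on this read-out lower numbers stand for a stronger effect and higher numbers for a weaker effect at the one concentration tested. Compound 1 is nearest to compound 3, with a number 4 percentage points lower from compound 1 to compound 3 (within the scatter), and compound 2 is reached by a number 7 percentage points lower from compound 1 to compound 2 (within the scatter); every one of these gaps lies within the scatter, so no order among the three can be read from them.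

Compound 4 `COc1ccc(-c2cc(/C=C/C(=O)c3ccc(N)cc3)[nH]n2)cc1OC` has not been measured. It differs from compound 1 by hydrogen in place of methoxy on an aromatic carbon. The same kind of change has been measured once already, from compound 2 to compound 3: hydrogen in place of methoxy on an aromatic carbon, which gave a number 3 percentage points higher from compound 2 to compound 3 (within the scatter). The surroundings are not identical, though: in compound 1 the aromatic carbon that loses the methoxy is also meta to a methoxy group, and the two cores differ by 4-aminophenyl in place of 3,4-dimethoxyphenyl on a carbonyl carbon.

Resting on that measured step, the expected change is a number 3 percentage points lower from compound 1 to compound 4 (within the scatter). The expectation is small because compound 3 gives 102% after the same kind of change. Compound 4 is therefore estimated at 103%, between 92% and 114%.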

Compound 4, a percentage reported as activity, at one concentration (the size of the read-out at that concentration, not a potency): 102%
For compound 4 the middle estimate is 1 percentage points above the measured one; the measured number falls inside the stated range.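

In this assay hydrogen in place of methoxy on an aromatic carbon gives a number 4 percentage points lower from compound 1 to compound 4 (within the scatter), so on the core of compound 1 this swap shows no effect that can be told from scatter. The change therefore looks equally silent on both cores at the one concentration tested, but neither core shows a step of real size. This says nothing about whether a real effect, if one appeared under other conditions, would carry from one core to the other. The two steps themselves do not disagree, which is all the comparison can support: the same change on two cores in this assay, a number 3 percentage points higher (within the scatter) from compound 2 to compound 3 and a number 4 percentage points lower (within the scatter) from compound 1 to compound 4, 7 percentage points apart, within the scatter of two such steps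

The compounds shown leave open whether a hydroxyl group, a chlorine atom or a longer chain such as ethoxy on that aromatic carbon would give a read-out any different from methoxy or hydrogen. Going by these compounds, it also stays open whether the swap would remain as silent on a core carrying a carboxylic acid on the phenyl ring attached to the carbonyl carbon.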